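The source may hold more compounds than are shown below. What is called first, only, known or untested is meant among the compounds shown, and "the series" means these compounds.

Compound 1 `CS(=O)(=O)c1nn2cc(-c3cc4ccccc4o3)nc2s1` is recorded as "not determined" (no result reported) in an ADME assay on microsomes from liver (Homo sapiens) for metabolic stability, with a stated time of 10 min; on this read-out lower numbers stand for a less stable compound and higher numbers for a more stable compound. Among the measured compounds shown here, compound 2 `COc1cc(OCc2cccc(O)c2)c2cc(-c3cn4nc(OC)sc4n3)oc2c1` gives 97% in this assay, the only number in the set, so it stands alone with nothing to compare against. Compound 3 `COc1cc(OCc2cccc(C#N)c2)c2cc(-c3cn4nc(OC)sc4n3)oc2c1` differs from compound 2 by cyano in place of hydroxy on an aromatic carbon. For the measured compounds named here, no measured step covers such a change here, and with compound 2 already near full retention, the step from compound 2 to compound 3 in this assay is expected to stay within the usual scatter, a number 3 percentage points lower from compound 2 to compound 3 (within the scatter). Compound 3 is therefore estimated at 94%, with an expected range of 80% to 100%.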

Compound 3, percent of the compound remaining: 100%
Beside the measured number, compound 3's estimate is 6 percentage points below it, and the stated range covers the measured number.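

Cyano in place of hydroxy on this aromatic carbon gives the first readable step in this assay, with a number 3 percentage points higher from compound 2 to compound 3 (within the scatter) on the move from 3-hydroxybenzyl to 3-cyanobenzyl. This position therefore tolerates the loss of the hydrogen-bond donor without a shift beyond the scatter, although both compounds sit near the top of the read-out. No available data explain this result. Still open, from the compounds shown here alone, is how an amine or a carboxylic acid would read on this aromatic carbon. Also open, going by these compounds, is whether a longer chain in place of the benzyl link would hold up.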